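The compounds below may be only part of what the source reports. "The series", "measured", "known", "first", "only" and "open" are said of these compounds alone.

Compound 1 `COc1cc(OC)c2sc(-c3ccc(N/C=C\C(=O)c4ccc(OC)c(O)c4)cc3)nc2c1` and compound 2 `COc1cc(OC)c2sc(-c3ccc(N/C=C\C(=O)c4ccc(OC)c([N+](=O)[O-])c4)cc3)nc2c1` share one core and differ in a single place, (nitro in place of hydroxy on an aromatic carbon). In a functional assay on MIA PaCa-2 cells (Homo sapiens) for antiproliferative activity, read by sulforhodamine B assay, with a stated time of 48 h (on this read-out higher numbers stand for weaker inhibition and lower numbers for stronger inhibition), compound 1 gives 11600 nM, while compound 2 gives 2900 nM, so that this change made a 4.0-fold lower number from compound 1 to compound 2 (0.60 log units; beyond the scatter). Compound 3 `COc1ccc2nc(-c3ccc(N/C=C\C(=O)c4ccc(OC)c(O)c4)cc3)sc2c1` carries the same hydroxy group on another core; the difference between the two cores is not broken down here. In this assay compound 3 gives 21900 nM, a number that lies within the scatter of compound 1 and beyond it from compound 2. Compound 4 `COc1ccc2nc(-c3ccc(N/C=C\C(=O)c4ccc(OC)c([N+](=O)[O-])c4)cc3)sc2c1` has not yet been measured. It stands to compound 3 as compound 2 stands to compound 1, with nitro in place of hydroxy on an aromatic carbon, and the place of the change is the same in both pairs. Since the same change gave a 4.0-fold lower number from compound 1 to compound 2 (0.60 log units; beyond the scatter) and compound 1 and compound 3 lie within the scatter of each other, a step of like size is expected, a 4.0-fold lower number from compound 3 to compound 4 (0.60 log units; beyond the scatter). Compound 4 is therefore estimated at 5500 nM in this assay, with a range from 2500 nM to 12000 nM.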

Compound 4, half-maximal inhibitory concentration: 23600 nM
For compound 4 the middle estimate is 4.3-fold (0.63 log units) below the measured one; the measured number lies above the stated range.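

On the second core, nitro in place of hydroxy did not repeat what it did on the first: in this assay the change gave a 1.1-fold higher number from compound 3 to compound 4 (0.03 log units; within the scatter). Set side by side, the two steps do not agree, so within these four compounds the effect of the change did not carry from one core to the other: the same change on two cores in this assay, a 4.0-fold lower number (0.60 log units; beyond the scatter) from compound 1 to compound 2 and a 1.1-fold higher number (0.03 log units; within the scatter) from compound 3 to compound 4, 4.3-fold (0.63 log units) apart, beyond the scatter of two such steps. This shows that a step read on one of these cores could not be taken over to the other, but it does not show which feature of the two cores separates the steps, and with one pair on each core it gives no general rule for the series.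

The compounds shown carry only hydroxy or nitro at this place, and how an amine or a carboxylic acid there would read on either core stays open. For the compounds shown here, only two cores appear, and whether a third would follow the step of one or the other also stays open.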